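The source may hold more compounds than are shown below. What is called first, only, known or untested is meant among the compounds shown, and "the series" means these compounds.

Compound 1, with the structure `Cc1c(Nc2nc(N)c3c(C#N)c(N4CCC[C@H]4C)n(C)c3n2)cnn1C`, is the starting point of this small set. In an ADME assay on microsomes from liver (Homo sapiens) for pharmacokinetics (on this read-out higher numbers stand for fast clearance and lower numbers for slow clearance), compound 1 gives 41.7 mL/min/kg. Compound 2, with the structure `Cc1c(Nc2nc(N)c3c(C#N)c(N4CCC[C@H]4C)n(C)c3n2)cnn1CC1(O)COC1`, is built from it by one change, (3-hydroxyoxetan-3-yl in place of hydrogen on a saturated chain carbon bound to an aromatic nitrogen), and in this assay compound 2 gives 35 mL/min/kg. The step this change made is a 1.2-fold lower number from compound 1 to compound 2 (0.08 log units; within the scatter).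

Compound 3, with the structure `Cc1nn(C)cc1Nc1nc(N)c2c(C#N)c(N3CCC[C@H]3C)n(C)c2n1`, carries a different core from compound 1; the two cores differ as described by 1,3-dimethyl-1H-pyrazol-4-yl in place of 1,5-dimethyl-1H-pyrazol-4-yl on a nitrogen on an aromatic ring. In this assay compound 3 gives 70 mL/min/kg, and the step between them is a 1.7-fold higher number from compound 1 to compound 3 (0.22 log units; within the scatter).

Compound 4, with the structure `Cc1nn(CC2(O)COC2)cc1Nc1nc(N)c2c(C#N)c(N3CCC[C@H]3C)n(C)c2n1`, has not yet been measured. For the measured compounds named here, it is related to compound 3 by the change (3-hydroxyoxetan-3-yl in place of hydrogen on a saturated chain carbon bound to an aromatic nitrogen), and this is the same change as the one that led from compound 1 to compound 2, since the place it sits in is described in the same words for both pairs. Among the compounds shown, this change appears twice in all.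

Going by the values given here, the expected step from compound 3 to compound 4 in this assay is a 1.2-fold lower number from compound 3 to compound 4 (0.08 log units; within the scatter), and this expectation rests on the one measured example, a 1.2-fold lower number from compound 1 to compound 2 (0.08 log units; within the scatter), together with the starting value of compound 3, 70 mL/min/kg. On that basis compound 4 is estimated to give 58 mL/min/kg, with a range from 35 mL/min/kg to 95 mL/min/kg.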

Compound 4, clearance: 76.7 mL/min/kg
Beside the measured number, compound 4's estimate is 1.3-fold (0.12 log units) below it, within the range that was stated.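

In this assay, the change from methyl to (3-hydroxyoxetan-3-yl)methyl gives a 1.1-fold higher number from compound 3 to compound 4 (0.04 log units; within the scatter), a step no larger than repeated measurements of one compound could produce. The earlier example reads the same way, so the change behaves alike on the two cores shown: the same change on two cores in this assay, a 1.2-fold lower number (0.08 log units; within the scatter) from compound 1 to compound 2 and a 1.1-fold higher number (0.04 log units; within the scatter) from compound 3 to compound 4, 1.3-fold (0.12 log units) apart, within the scatter of two such steps. This supports a modest statement, that on these two closely related cores the added 3-hydroxyoxetan-3-yl group makes no difference to clearance that can be told from the scatter; it does not show that the same would hold on a more distant core, and two pairs in a single assay cannot explain why the numbers stay so close or predict any other read-out.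

The compounds shown leave open whether a different group at this place, on a saturated chain carbon bound to an aromatic nitrogen, such as an amine, a carboxylic acid or a longer chain, would give a step beyond the scatter. They also leave open how the 3-hydroxyoxetan-3-yl group would read on a core with a primary amide in place of the nitrile.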